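Aminomethyl to 1-aminoethyl: compound 2 to compound 4

The source may report more compounds than this note shows. Statements on the series, on what has been measured and on what is new or still open speak of the compounds shown alone.

Compound 2 `Cc1ccc(N2CCN(C(=O)[C@@H]3CN(C4CCOCC4)C[C@H]3c3ccc(Cl)cc3)CC2)c([C@@H](NC(=O)CN)C(C)C)c1` holds the lowest number of the three measured compounds: in a functional assay on CHO cells for agonist activity at Melanocortin receptor 4 (Homo sapiens), read by cAMP accumulation (on this read-out lower numbers stand for an effect already at smaller amounts and higher numbers for an effect only at larger amounts of compound), compound 2 gives 9.1 nM. Compound 1 `CCC(=O)N1C[C@@H](C(=O)N2CCN(c3ccc(C)cc3[C@@H](NC(=O)CCN(C)C)C(C)C)CC2)[C@H](c2ccc(Cl)cc2)C1` gives 27 nM in this assay, a gap beyond the scatter, and compound 3 `CC(C)[C@H](NC(=O)CCN(C)C)c1cccc(F)c1N1CCN(C(=O)[C@@H]2CN(C(C)C)C[C@H]2c2ccc(F)c(Cl)c2)CC1` gives 410 nM in this assay, the furthest off. Compound 4 `Cc1ccc(N2CCN(C(=O)[C@@H]3CN(C4CCOCC4)C[C@H]3c3ccc(Cl)cc3)CC2)c([C@@H](NC(=O)[C@H](C)N)C(C)C)c1` differs from compound 2 in one place: methyl in place of hydrogen on a saturated chain carbon bound to an amine nitrogen and a carbonyl carbon. Among the measured compounds shown here, no measured pair shows this change, so no step can be read off. The expected step in this assay, a 1.3-fold lower number from compound 2 to compound 4 (0.11 log units; within the scatter), is small and within the scatter, if anything toward a lower number. Compound 4 is estimated at 7 nM, within 2.5 nM to 25 nM.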

Compound 4, half-maximal effective concentration: 5.2 nM
Compound 4: middle estimate off by 1.3-fold (0.13 log units), on the high side; low and high end bracket the measured number.
By their numbers in this assay, from the lowest: compounds 4 and 2 (each within the scatter of the next); then compound 1; then compound 3.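

In this assay, among the compounds shown here, the first pair of the series differing in one place gives a 1.8-fold lower number from compound 2 to compound 4 (0.24 log units; within the scatter) and so shows that methyl in place of hydrogen on a saturated chain carbon bound to an amine nitrogen and a carbonyl carbon is accepted, with no change beyond the scatter. Nothing at hand explains the size of this step. Going by these compounds, whether an ethyl group, a second methyl or the opposite configuration at this carbon keeps the number in the same range stays open.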